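Changing the Aryl Group on the Shared Core

The source may report more compounds than this note shows. Statements on the series, on what has been measured and on what is new or still open speak of the compounds shown alone.

Within the data shown here, in a functional assay (muscle tissue) with Cavia porcellus as the target (on this read-out lower numbers stand for an effect already at smaller amounts and higher numbers for an effect only at larger amounts of compound), compound 1 (`COC(=O)C1=C(C)N=C(C)/C(=C(\O)OC)C1c1ccccc1N`) gives 39800 nM and compound 2 (`COC(=O)C1=C(C)N=C(C)/C(=C(\O)OC)C1c1cccc(O)c1`) gives 1000 nM as the lower of the two numbers so far. The measured change is a 40-fold lower number from compound 1 to compound 2 (1.60 log units; beyond the scatter) and lies well beyond the scatter; it comes with 3-hydroxyphenyl in place of 2-aminophenyl on a saturated ring carbon. Compound 3 (`COC(=O)C1=C(C)N=C(C)/C(=C(\O)OC)C1c1ccc(F)cc1`) differs from compound 2 at that same carbon by 4-fluorophenyl in place of 3-hydroxyphenyl on a saturated ring carbon and carries 4-fluorophenyl in place of 3-hydroxyphenyl. Only the large step of a 40-fold lower number from compound 1 to compound 2 (1.60 log units; beyond the scatter) bears on this change. It shows that the group on this carbon can move the number strongly, yet neither of its compounds carries 4-fluorophenyl. A smaller, upward step is therefore expected. The expected change is a 2.5-fold higher number from compound 2 to compound 3 (0.40 log units; beyond the scatter) in this assay and would be modest beside the measured one. Compound 3 is estimated at 2500 nM with an expected range from 500 nM to 12500 nM in this read-out.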

Compound 3, half-maximal effective concentration: 129 nM
The estimate for compound 3 lay 19-fold (1.29 log units) above the measured number; the measured number lies below the stated range.
By their numbers in this assay, from the lowest: compound 3; then compound 2; then compound 1.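

In this assay, the step of a 7.8-fold lower number from compound 2 to compound 3 (0.89 log units; beyond the scatter) came with 4-fluorophenyl, which has 0 hydrogen-bond donors and 0 hydrogen-bond acceptors, in place of 3-hydroxyphenyl, so a hydroxyl group on the aryl ring is not required for the lowest number seen so far at this saturated ring carbon. The full span across the aryl groups now reaches a 310-fold lower number from compound 1 to compound 3 (2.49 log units; beyond the scatter), which shows that this one carbon can carry changes much larger than the first step alone revealed. Nothing available explains why 4-fluorophenyl gives the lowest number.

The three aryl groups differ both in their substituent and in where it sits on the phenyl ring, so these two changes cannot be separated. On these data alone, how an unsubstituted phenyl, a chlorophenyl or a nitrophenyl group would compare also remains open.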